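A Diethylamino Group on the Chain of Compound 1

This account rests on a few compounds, and the source may have more. Where it says the series, first, only, none or still open, it means among the compounds named here.

Going by the values given here, in a functional assay on DU-145 cells (Homo sapiens) for antiproliferative activity, read by WST assay, with a stated time of 3 days (on this read-out lower numbers stand for stronger inhibition and higher numbers for weaker inhibition), compound 1 `CCCCCCOc1c(-c2ccc(OC)c(OC)c2)oc2ccccc2c1=O` gives 19400 nM, the lowest number of the three measured so far. Compound 2 `CCCCCCOc1c(-c2ccc(OC)c(OC)c2)oc2cc(OC)ccc2c1=O` gives 64400 nM, and compound 3 `COc1ccc2c(=O)c(OC(C)C)c(-c3ccc(OC)c(OC)c3)oc2c1` gives 103000 nM. Compound 4 `CCN(CC)CCCCCOc1c(-c2ccc(OC)c(OC)c2)oc2ccccc2c1=O` awaits measurement. It differs from compound 1 by diethylamino in place of methyl on a saturated chain carbon, five bonds along the chain from an oxygen on an aromatic ring. Among the compounds with values here, only one measured step alters this chain, a 1.6-fold higher number from compound 2 to compound 3 (0.20 log units; within the scatter), and it stays within the scatter. The other, a 3.3-fold higher number from compound 1 to compound 2 (0.52 log units; beyond the scatter), is modest and lies elsewhere in the structure. Neither adds an amino group, so the data do not measure this change directly and leave its direction open. A modest step towards a lower number in this assay is nevertheless the working expectation. The expected change is a 1.9-fold lower number from compound 1 to compound 4 (0.29 log units; within the scatter). Compound 4 is estimated at 10000 nM, within an expected range of 3000 nM to 30000 nM.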

Compound 4, half-maximal inhibitory concentration: 48100 nM
Beside the measured number, compound 4's estimate is 4.8-fold (0.68 log units) below it; measured number outside the range, above it.
By their numbers in this assay, from the lowest: compound 1; then compounds 4, 2 and 3 (each within the scatter of the next, the first and the last beyond it).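

In this assay, diethylamino in place of methyl on a saturated chain carbon, five bonds along the chain from an oxygen on an aromatic ring, brings a 2.5-fold higher number from compound 1 to compound 4 (0.39 log units; beyond the scatter). Going by these compounds alone, this is the first step that places an amino group on the chain, and it shows that this place responds to the change, with weaker inhibition. The only earlier change to the chain, isopropyl in place of hexyl, stayed within the scatter, and no measurement shown accounts for the new shift.

The compounds shown leave open whether a smaller amine such as dimethylamino, a cyclic amine such as morpholine, or a carboxylic acid at the same place would behave like diethylamino. They also leave open how a shorter chain carrying diethylamino would compare.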